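Aryl swap on the saturated ring carbon of the pyrazoline series

A few compounds are considered here, and "the series" means these few. Any claim that something is new, unique, unknown or untested is made for them only; others in the source may bear on it.

Three members of the series have been run in a functional assay on the whole organism (strain albino) with Rattus norvegicus as the target, read by paw edema, with stated times of 1 h and 4 h, at a dose of 50 mg/kg by the oral route; on this read-out higher numbers stand for a stronger effect at the one dose given and lower numbers for a weaker effect. Compound 1 `COc1ccc(Cl)cc1C(=O)Nc1ccc(C2=NN(C)C(c3ccc([N+](=O)[O-])cc3)C2)cc1` gives 97.4%. Compound 2 `COc1ccc(C2CC(c3ccc(NC(=O)c4cc(Cl)ccc4OC)cc3)=NN2)cc1` gives 89%. Compound 3 `COc1ccc(Cl)cc1C(=O)Nc1ccc(C2=NNC(c3ccccc3[N+](=O)[O-])C2)cc1` gives 90.9% in this assay. All three numbers lie within the usual scatter of one another, so compound 3 cannot be set apart from compound 1 or compound 2 on these data.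

The step from compound 3 to compound 4 `COc1ccc(Cl)cc1C(=O)Nc1ccc(C2=NNC(c3ccc([N+](=O)[O-])cc3)C2)cc1` is 4-nitrophenyl in place of 2-nitrophenyl on a saturated ring carbon.

For the measured compounds named here, one measured step bears on this change, because it too exchanges the aryl group on a saturated ring carbon of the five-membered non-aromatic ring with two nitrogens: a number 1.9 percentage points higher from compound 2 to compound 3 (within the scatter). Compound 1 also carries 4-nitrophenyl at this position, yet it differs from compound 4 in a second place as well, so its value stands only as a further point in the same range. No exchange of the aryl group on this ring carbon has so far moved the read-out beyond the scatter.

The expected step in this assay is therefore a number 2.1 percentage points higher from compound 3 to compound 4 (within the scatter), with no change beyond the scatter foreseen. Compound 4 is estimated at 93%, in the range from 84% to 100%.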

Compound 4, a percentage reported as activity, at one dose (the size of the read-out at that dose, not a potency): 95.3%
The estimate for compound 4 lay 2.3 percentage points below the measured number; measured number inside the range.
By their numbers in this assay, from the lowest: compounds 2, 3, 4 and 1 (each within the scatter of the next).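

Moving the nitro group around the aryl ring, with the atoms otherwise unchanged, gives a number 4.4 percentage points higher from compound 3 to compound 4 (within the scatter) in this assay, so the two placements on this saturated ring carbon cannot be told apart on this read-out. Compound 4 also closes two further single-place comparisons: nitro in place of methoxy on an aromatic carbon gives a number 6.3 percentage points higher from compound 2 to compound 4 (within the scatter), and hydrogen in place of methyl on the amine nitrogen in a ring gives a number 2.1 percentage points lower from compound 1 to compound 4 (within the scatter), so neither the aryl substituent nor the substituent on that ring nitrogen has yet shifted this assay beyond the scatter. No evidence is at hand on what lies behind these steps.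

The compounds shown do not settle whether any change at this position can separate members of the series, since every step here stays within the scatter at a single dose. As far as these compounds go, it remains open how an amine or a carboxylic acid on this aryl ring, or a longer chain in place of methyl on the ring nitrogen, would read in this assay.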